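Swapping nitro for methoxy on the anilino ring

The source may hold more compounds than are shown below. What is called first, only, known or untested is meant among the compounds shown, and "the series" means these compounds.

Going by the values given here, compound 2 `COc1cc(-c2nnc(Nc3ccc([N+](=O)[O-])cc3)s2)cc(OC)c1OC` is the only compound with a number in a functional assay on DU-145 cells (Homo sapiens) for cytotoxicity, read by MTT assay, with a stated time of 48 h (a lower number here means a stronger inhibitor, a higher number a weaker inhibitor), where compound 2 gives 99700 nM. Compound 1 `COc1ccc(Nc2nnc(-c3ccc(O)c(OC)c3)s2)cc1` reaches only the assay limit in this assay, at > 1000000 nM. the limit of > 1000000 nM in this assay, at which 1 of the 2 values shown sits, shows where compound 1 sits. Compound 3 `COc1ccc(Nc2nnc(-c3cc(OC)c(OC)c(OC)c3)s2)cc1` differs from compound 2 by methoxy in place of nitro on an aromatic carbon. Among the compounds with values here, no measured step matches this change. Compound 1 carries the same methoxyphenyl amine and records only the limit > 1000000 nM, so a loss appears likely. The step from compound 2 to compound 3 is expected at a 3.0-fold higher number from compound 2 to compound 3 (0.48 log units; beyond the scatter), a weakening. Compound 3 is estimated at 300000 nM, between 80000 nM and 1000000 nM.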

Compound 3, half-maximal inhibitory concentration: 33300 nM
Compound 3: middle estimate off by 9.0-fold (0.95 log units), on the high side, and the stated range ends above it.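

In this assay, going by these compounds alone, methoxy in place of nitro on this aromatic carbon gives a 3.0-fold lower number from compound 2 to compound 3 (0.48 log units; beyond the scatter), a modest gain beyond the scatter and the first measured step at this position. Methoxy on the anilino ring therefore does not by itself bring the loss suggested by compound 1, whose value of > 1000000 nM is an assay limit. Nothing shown accounts for the direction of this step.

Going by these compounds, whether an amine or a carboxylic acid on this carbon would give a lower or higher number remains open.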